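This account rests on a few compounds, and the source may have more. Where it says the series, first, only, none or still open, it means among the compounds named here.

Measured compounds in an ADME assay on microsomes from liver (Homo sapiens) for metabolic stability, with a stated time of 30 min; on this read-out lower numbers stand for a less stable compound and higher numbers for a more stable compound:

compound 1, `Cc1nc(N(C)C2CCCC2)nc2ccc(NC(=O)/C=C/c3ccc(Cl)cc3)cc12`: "not determined" (no result reported)
compound 2, `Cc1nc(N2CCC(N3CCNC3=O)CC2)nc2ccc(NC(=O)/C=C/c3ccc(OC(F)(F)F)cc3)cc12`: 83%

Going by the values given here, compound 2 thus stands as the only entry with a number in this assay; compound 1 was run without a reported result, so no comparison between the two can be drawn. Compound 3, `Cc1nc(N2CCC(N3CCCC3=O)CC2)nc2ccc(NC(=O)/C=C/c3ccc(OC(F)(F)F)cc3)cc12`, is not yet measured. Its structure departs from compound 2 in one place: 2-oxopyrrolidin-1-yl in place of 2-oxoimidazolidin-1-yl on a saturated ring carbon. The change keeps the ring size and the carbonyl but exchanges one ring nitrogen for a ring carbon, and with it the single hydrogen-bond donor is lost. Among the compounds with values here, no measured pair shows what such an exchange does in this assay, so the direction of the step has to be guessed. Compound 3 is expected to give 75%, with a range from 55% to 92%. The estimated step of a number 8 percentage points lower from compound 2 to compound 3 (within the scatter) is expected to be a small downward move that may not exceed the usual scatter.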

Compound 3, percent of the compound remaining: 76%
Compound 3: the middle estimate sits 1 percentage points below what was measured; measured number inside the range.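

In this assay, placing 2-oxopyrrolidin-1-yl in place of 2-oxoimidazolidin-1-yl on the saturated ring carbon gives a number 7 percentage points lower from compound 2 to compound 3 (within the scatter), so the two compounds cannot be told apart on this read-out. Going by these compounds alone, this is the first measured pair, and it shows that a compound without the hydrogen-bond donor of the 2-oxoimidazolidin-1-yl group can stay within the scatter of one that carries it, at least with the rest of the structure held as in these two compounds. Nothing available gives a reason for this outcome.

Still open, from the compounds shown here alone, is how an amine, a carboxylic acid or a longer chain on this saturated ring carbon would read in this assay. Also open, going by these compounds, is whether the pair would behave alike with 4-chlorophenyl in place of the 4-(trifluoromethoxy)phenyl group, as compound 1 has no result to compare.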